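This account rests on a few compounds, and the source may have more. Where it says the series, first, only, none or still open, it means among the compounds named here.

Compound 2 `c1ccc(-c2ccc(Cn3cncc3CNc3ccc(-c4onc5ccccc45)c(-c4ccccc4)c3)cc2)cc1` was examined in a toxicity assay on NIH3T3 cells (Mus musculus) for cytotoxicity, read by resazurin assay (on this read-out lower numbers stand for an effect already at smaller amounts and higher numbers for an effect only at larger amounts of compound), and compound 2 gives only a limit there, > 10000 nM, so no number is known for it. Among the three entries shown, compound 2 sits at the limit of > 10000 nM in this assay, at which 1 of the 3 values shown sits, the higher of the two limits. Compound 1 `Nc1cc(-c2ccccc2)ccc1Cn1cncc1CNc1ccc(-c2cncs2)c(-c2ccccc2)c1` likewise reaches only a limit in this assay, > 1000 nM, which is the limit of > 1000 nM in this assay, at which 1 of the 3 values shown sits. For compound 3 `COC(=O)c1ccc(NCc2cncn2Cc2cccc(OC)c2)cc1-c1ccccc1` the entry in this assay is "not determined" (no result reported). Going by the values given here, no two measured compounds differ in a single place, so no measured step is available to set a scale.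

Compound 4 `N#Cc1ccc(NCc2cncn2Cc2ccc(-c3ccccc3)cc2)cc1-c1ccccc1` is the one still to be measured in this assay. It differs from compound 2 by a group of 2 heavy atoms (1 carbon, 1 nitrogen; no ring) in place of a group of 9 heavy atoms (7 carbon, 1 nitrogen, 1 oxygen; one five-membered aromatic ring with 2 hetero atoms, one six-membered aromatic ring of carbon only), on an aromatic carbon.

Since compound 2 only reaches a limit in this assay, the step from compound 2 to compound 4 is expected to be a step that the limit leaves unreadable from compound 2 to compound 4, that is, none beyond the scatter as far as it can be judged. Compound 4 is therefore estimated at 20000 nM, with a range from 5000 nM to 100000 nM, and most likely the assay again reports only a limit.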

Compound 4, half-maximal effective concentration: > 1000 nM
Compound 4 gave a limit, no number; the forecaster's own chance of this, stated with the estimate: 80%; the middle value does not contradict the limit.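

Compound 2 and compound 4 both give only limits in this assay, and the step between them cannot be read. The compounds shown leave open what actual value any of them would reach, and whether cyano in place of the larger group changes the read-out at all.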